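Compound 3 to compound 4: a small change on the amide

This account rests on a few compounds, and the source may have more. Where it says the series, first, only, none or still open, it means among the compounds named here.

Of the compounds shown here, three have been measured in an ADME assay on HEp-2 cells (Homo sapiens) for cytotoxicity; a lower number here means that less compound is tolerated, a higher number that more compound is tolerated. Compound 1 (`Cc1ccc(NC(=O)C(C)NS(=O)(=O)c2cccc3cccnc23)c(C)c1`) gives only a limit, > 50000 nM. Compound 2 (`Cc1ccnc(C)c1NC(=O)[C@@H]1CCCN1S(=O)(=O)c1cccc2cccnc12`) also gives only a limit, > 50000 nM. The picture so far therefore rests largely on (the limit of > 50000 nM in this assay, at which 2 of the 3 values shown sit). Going by the values given here, compound 3 (`Cc1cc(C)cc(NC(=O)[C@@H]2CCCN2S(=O)(=O)c2cccc3cccnc23)c1`) is the only one with an actual number, 31300 nM.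

Compound 4 (`COc1ccc(C)c(NC(=O)[C@@H]2CCCN2S(=O)(=O)c2cccc3cccnc23)c1`) has 5-methoxy-2-methylphenyl in place of 3,5-dimethylphenyl on an amide-type nitrogen. Among the compounds with values here, the one measured step at this place is an at least 1.5-fold lower number from compound 2 to compound 3 (0.20 log units; that floor lies within the scatter). It exchanges a different group, and its size is bounded on one side only, so it offers no firm guide to the new change. The expectation therefore starts from compound 3 at 31300 nM, with no shift beyond the scatter foreseen in this assay. The expected step is a 1.1-fold higher number from compound 3 to compound 4 (0.02 log units; within the scatter). For compound 4 the estimated value is 33000 nM, with an expected range of 15000 nM to 50000 nM.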

Compound 4, half-maximal cytotoxic concentration: 44200 nM
Compound 4: middle estimate off by 1.3-fold (0.13 log units), on the low side, and the stated range covers the measured number.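

In this assay, the exchange of 3,5-dimethylphenyl for 5-methoxy-2-methylphenyl on an amide-type nitrogen gives a 1.4-fold higher number from compound 3 to compound 4 (0.15 log units; within the scatter). Going by these compounds alone, this is the first step at this place with a real number at both ends, and it shows that this exchange, which adds a methoxy group, causes no shift beyond the scatter. Compound 2 gives only a limit, so the exchange of 2,4-dimethylpyridin-3-yl for 5-methoxy-2-methylphenyl reads as an at least 1.1-fold lower number from compound 2 to compound 4 (0.05 log units; that floor lies within the scatter) and fixes no size, and the series still leans on that ceiling: the limit of > 50000 nM in this assay, at which 2 of the 4 values shown sit.

The compounds shown do not separate what the methoxy group and the methyl group of 5-methoxy-2-methylphenyl each contribute. On these data alone, it also remains open whether a carboxylic acid or an aminomethyl group on this ring would move the number beyond the scatter.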